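Adding a Methoxy Group to Compound 2

A few compounds are considered here, and "the series" means these few. Any claim that something is new, unique, unknown or untested is made for them only; others in the source may bear on it.

In a functional assay on MCF7 cells (Homo sapiens) for inhibition, read by MTT assay, with a stated time of 48 h (on this read-out lower numbers stand for stronger inhibition and higher numbers for weaker inhibition), compound 2 `c1ccc(-c2ccnc3c2c(-c2ccccc2)nn3-c2ccccc2)cc1` gives 28200 nM and compound 3 `O=C(C=CNc1cc(-c2ccccc2)nn1-c1ccccc1)c1ccc(Br)cc1` gives 21700 nM, two values within the usual scatter of each other. Compound 1 `COc1ccc(-c2nc3c(c(-c4ccccc4)nn3-c3ccccc3)c(-c3ccc(N4CCCCC4)cc3)c2C#N)cc1` gives 2760 nM, a number lower than both and beyond the scatter, so compound 2 sits at the weak end of this small set. Compound 4 `COc1ccc(-c2ccnc3c2c(-c2ccccc2)nn3-c2ccccc2)cc1` turns a phenyl into a 4-methoxyphenyl: methoxy in place of hydrogen on an aromatic carbon, with methoxy in place of hydrogen on an aromatic carbon, para to a large group. Among the measured compounds shown here, no measured pair shows this change alone. Compound 1, at 2760 nM, also carries a methoxy group but differs in several other places, so it offers only a weak hint toward a lower number. The expected change, a 1.6-fold lower number from compound 2 to compound 4 (0.19 log units; within the scatter), is small and may stay within the scatter. Compound 4 is estimated at 18000 nM, with an expected range of 7000 nM to 40000 nM.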

Compound 4, half-maximal inhibitory concentration: 28700 nM
Compound 4: the middle estimate sits 1.6-fold (0.20 log units) below what was measured; the measured number falls inside the stated range.
By their numbers in this assay, from the lowest: compound 1; then compounds 3, 2 and 4 (each within the scatter of the next).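

In this assay, among the compounds shown here, this is the first direct reading of this change: putting methoxy in place of hydrogen, turning phenyl into 4-methoxyphenyl, gives a 1.0-fold higher number from compound 2 to compound 4 (0.01 log units; within the scatter). At this position on the ring, para to a large group, the methoxy group therefore leaves compound 2 and compound 4 indistinguishable in this assay. Nothing measured here offers an explanation for this result.

On these data alone, whether an amine, a carboxylic acid or a longer chain such as butoxy at this position would shift the number remains open. A single substituent also cannot show whether this position responds to any change.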